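Furan-3-yl in place of the nitrile-bearing aryl group

The source may hold more compounds than are shown below. What is called first, only, known or untested is meant among the compounds shown, and "the series" means these compounds.

For the measured compounds named here, in an assay on NIH3T3 cells for inhibition of Sonic hedgehog protein (Mus musculus), read by a luciferase reporter, with a stated time of 48 h (on this read-out lower numbers stand for stronger inhibition and higher numbers for weaker inhibition), compound 2 `Cc1cnc(Nc2ccc(C(=O)Nc3c(C)cccc3C)cc2)nc1-c1ccc(C#N)cc1` gives 2.8 nM, the lowest of the two numbers so far; compound 1 `Cc1cnc(Nc2ccc(C(=O)Nc3c(C)cccc3C)cc2)nc1-c1ccc(OC(F)(F)F)c(F)c1` gives 159 nM. Compound 3 `Cc1cnc(Nc2ccc(C(=O)Nc3c(C)cccc3C)cc2)nc1-c1ccoc1` differs from compound 2 by furan-3-yl in place of 4-cyanophenyl on an aromatic carbon. Going by the values given here, the only step bearing on this position is a 57-fold lower number from compound 1 to compound 2 (1.75 log units; beyond the scatter), which shows that the group here can move the number a great deal. Among the compounds with values here, no measured step swaps the six-membered aromatic ring for a five-membered aromatic ring, so the direction rests on that single step alone. Compound 3 is expected to give a higher number, estimated at 40 nM within 5 nM to 400 nM, meaning a 14-fold higher number from compound 2 to compound 3 (1.15 log units; beyond the scatter).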

Compound 3, half-maximal inhibitory concentration: 15.7 nM
Beside the measured number, compound 3's estimate is 2.5-fold (0.41 log units) above it, and the stated range covers the measured number.
By their numbers in this assay, from the lowest: compound 2; then compound 3; then compound 1.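

In this assay furan-3-yl gives a 5.6-fold higher number from compound 2 to compound 3 (0.75 log units; beyond the scatter) so this carbon accepts a five-membered aromatic ring with one hetero atom, although 4-cyanophenyl keeps the lower number. Against 3-fluoro-4-(trifluoromethoxy)phenyl the same ring gives a 10-fold lower number from compound 1 to compound 3 (1.01 log units; beyond the scatter) so a number well under that of compound 1 does not depend on the nitrile. No evidence on hand explains either step.

On these data alone, how much of the gap between compound 2 and compound 3 belongs to the nitrile and how much to the ring itself stays open. An unsubstituted phenyl ring or a phenyl ring bearing an amine at this carbon would help separate the two.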